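The compounds below may be only part of what the source reports. "The series", "measured", "known", "first", "only" and "open" are said of these compounds alone.

Compound 1 `COc1cccc(Oc2ccc3c(NCCCNCc4cc(F)ccc4OC)ccnc3c2)c1`: 9.28
Compound 2 `COc1ccc(F)cc1CNCCCNc1ccnc2cc(Oc3ccc(Cl)cc3)ccc12`: 9.28

In a physicochemical assay for acid dissociation, compound 2 gives 9.28 and stands level with compound 1 within the scatter. Compound 3 `COc1ccc(F)cc1CNCCCNc1ccnc2cc(Oc3ccccc3OC)ccc12` differs from compound 2 in one place: 2-methoxyphenyl in place of 4-chlorophenyl on an oxygen on an aromatic ring. Within the data shown here, the only measured step that bears on this is the one from compound 1 to compound 2, which also exchanged the group on that oxygen on an aromatic ring and read no change at the digits printed from compound 1 to compound 2 (within the scatter). On that basis a step of no change at the digits printed from compound 2 to compound 3 (within the scatter) is expected, that is, nothing beyond the scatter. Compound 3 is therefore estimated at 9.28, with a range from 8.95 to 9.6.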

Compound 3, acid dissociation constant: 9.28
For compound 3 middle estimate and measured number coincide at the digits printed; the range from low to high includes it.
By their numbers in this assay, from the lowest: compounds 1, 2 and 3 (each within the scatter of the next).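

In this assay, 2-methoxyphenyl in place of 4-chlorophenyl on the oxygen gives no change at the digits printed from compound 2 to compound 3 (within the scatter), and 2-methoxyphenyl in place of 3-methoxyphenyl gives no change at the digits printed from compound 1 to compound 3 (within the scatter). Three different substituted phenyl groups at this place, one carrying chlorine and two carrying methoxy, now share one reading, so this change has again left the number where it was.

Going by these compounds, whether a phenyl ring carrying an amine or a carboxylic acid at this place would also read level stays open. Nothing available explains this flat result.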